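The source may hold more compounds than are shown below. What is called first, only, known or untested is meant among the compounds shown, and "the series" means these compounds.

Compound 1 `O=C(Nc1cnc(NCc2c(F)ccc3c2CCO3)n2cnnc12)c1ccccc1` reads 3
Compound 2 `C[C@H]1CC(=O)N(c2cnc(NCc3c(F)ccc4c3CCO4)n3cnnc23)C1` reads 1.8

Both numbers come from a physicochemical assay for lipophilicity, using the shake flask method, in phosphate buffer, measured as octanol-water partition, with a stated time of 30 min, at pH 7.4; on this read-out higher numbers stand for higher lipophilicity and lower numbers for lower lipophilicity. Compound 2 is the lower of the two, and the gap to compound 1 lies beyond the usual scatter. The next compound, compound 3 `O=C1CC2(CC2)CN1c1cnc(NCc2c(F)ccc3c2CCO3)n2cnnc12`, keeps the shared core and changes one group: a group of 8 heavy atoms (6 carbon, 1 nitrogen, 1 oxygen; one three-membered non-aromatic ring of carbon only, one five-membered non-aromatic ring with 1 hetero atom) in place of a group of 7 heavy atoms (5 carbon, 1 nitrogen, 1 oxygen; one five-membered non-aromatic ring with 1 hetero atom), on an aromatic carbon.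

Among the measured compounds shown here, only one measured step bears on this change: a number 1.20 log units lower from compound 1 to compound 2 (beyond the scatter). That step was large and happened on the same aromatic carbon, but it replaced benzamido, a very different exchange. It shows that the number can move at this place, but it does not set a size for the present change. The two groups now being exchanged differ only slightly, so a small upward step is expected, possibly within the scatter. The expected step is a number 0.20 log units higher from compound 2 to compound 3 (within the scatter). For compound 3 the estimate is 2, with an expected range from 1.7 to 2.4.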

Compound 3, distribution coefficient: 1.9
Compound 3: middle estimate off by 0.10 log units, on the high side; the measured number falls inside the stated range.
By their numbers in this assay, from the lowest: compounds 2 and 3 (each within the scatter of the next); then compound 1.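

On this aromatic carbon, in this assay, the change from 4-methyl-2-oxopyrrolidin-1-yl to the group carrying a three-membered carbon ring gives a number 0.10 log units higher from compound 2 to compound 3 (within the scatter) and so cannot be told apart from no change, even though the new group has one more heavy atom and no defined stereocentre. Benzamido compared with this same group gives a number 1.10 log units lower from compound 1 to compound 3 (beyond the scatter) and this shows that the large step seen earlier is not unique to 4-methyl-2-oxopyrrolidin-1-yl but appears with a second five-membered ring group. Nothing measured here gives a reason for either step.

These compounds leave open where a simple acetamido group, with its open chain, would fall relative to benzamido and the two ring groups. They also leave open how a morpholine ring, an amine or a carboxylic acid would read on this aromatic carbon.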